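Compound 2 to compound 3: a halophenyl exchange

The compounds below may be only part of what the source reports. "The series", "measured", "known", "first", "only" and "open" are said of these compounds alone.

Two sulfonamides on the shared core end in a benzylic amine. Compound 1 `O=S(=O)(NCCCNCc1cccc2ccccc12)c1cc(C(F)(F)F)cc(C(F)(F)F)c1` gives 2800 nM in a functional assay on MIA PaCa-2 cells (Homo sapiens) for inhibition, read by MTT assay, with a stated time of 72 h; a lower number here means a stronger inhibitor of growth, a higher number a weaker inhibitor of growth. Going by the values given here, compound 2 `O=S(=O)(NCCCNCc1ccccc1Cl)c1cc(C(F)(F)F)cc(C(F)(F)F)c1` gives 11000 nM in this assay, the highest of the two numbers so far, and the only measured step, a 3.9-fold higher number from compound 1 to compound 2 (0.59 log units; beyond the scatter), lies beyond the scatter. Compound 3 `O=S(=O)(NCCCNCc1ccc(Br)cc1)c1cc(C(F)(F)F)cc(C(F)(F)F)c1` has not yet been measured. Its change from compound 2 is 4-bromophenyl in place of 2-chlorophenyl on a saturated chain carbon bound to an amine nitrogen. Among the compounds with values here, no measured step bears directly on this exchange: the single step seen, a 3.9-fold higher number from compound 1 to compound 2 (0.59 log units; beyond the scatter), swaps a naphthalen-1-yl for a 2-chlorophenyl, and nothing here compares a 2-chlorophenyl with a 4-bromophenyl. The account therefore expects compound 3 to remain close to the number of compound 2. The step of a 1.2-fold lower number from compound 2 to compound 3 (0.09 log units; within the scatter) is expected to fall within the scatter. Compound 3 is estimated at 9000 nM, with a range from 3000 nM to 27000 nM.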

Compound 3, concentration for 50% growth inhibition: 2300 nM
Beside the measured number, compound 3's estimate is 3.9-fold (0.59 log units) above it; the whole stated range lies above it.
By their numbers in this assay, from the lowest: compounds 3 and 1 (each within the scatter of the next); then compound 2.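

At this place, on a saturated chain carbon bound to an amine nitrogen, the exchange of 2-chlorophenyl for 4-bromophenyl gives a 4.8-fold lower number from compound 2 to compound 3 (0.68 log units; beyond the scatter) in this assay, so the choice of halophenyl group matters here. With a 1.2-fold lower number from compound 1 to compound 3 (0.09 log units; within the scatter), 4-bromophenyl and naphthalen-1-yl cannot be told apart, and the earlier rise, a 3.9-fold higher number from compound 1 to compound 2 (0.59 log units; beyond the scatter), therefore does not follow every single-ring replacement of naphthalen-1-yl. The data on hand offer no measurement that explains the difference between the two halophenyl groups.

The exchange changes both the halogen and its place on the ring, and the three compounds cannot separate these two changes; 4-chlorophenyl and 2-bromophenyl would do so. From the compounds shown here alone, how plain phenyl, or a longer chain between the sulfonamide and the amine, would read in this assay stays open.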